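A Second Chloro Group Enters the Core

The source may report more compounds than this note shows. Statements on the series, on what has been measured and on what is new or still open speak of the compounds shown alone.

Of the compounds shown here, two have so far been measured in a functional assay (Oryctolagus cuniculus) for inhibition; on this read-out higher numbers stand for weaker inhibition and lower numbers for stronger inhibition. Compound 1, `O=c1ccn(COCCO)c(=O)[nH]1`, gives only a limit in this assay, > 400 ug/mL, which is not a number. That limit is the limit of > 400 ug/mL in this assay, at which 1 of the 2 values shown sits. For the measured compounds named here, compound 2, `CC(=O)OCCOCn1cnc2c(Cl)ncnc21`, is the only compound with an actual number in this assay, where it gives 62 ug/mL. Going by the values given here, no two measured compounds differ in a single place, so no measured step is available to guide expectations. Compound 3, `CC(=O)OCCOCn1cnc2c(Cl)nc(Cl)nc21`, has yet to be measured in this assay. It differs from compound 2 by chloro in place of hydrogen on an aromatic carbon; the chloro enters between two ring nitrogen atoms, meta to a chloro group. Lacking any measured step, the change is expected to stay within the usual scatter or to move only modestly in either direction. Compound 3 is therefore estimated at 50 ug/mL in this assay, within a likely range from 15 ug/mL to 200 ug/mL. The expected step is a 1.2-fold lower number from compound 2 to compound 3 (0.09 log units; within the scatter).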

Compound 3, concentration for 50% inhibition: 2 ug/mL
Estimate against measurement, compound 3: 25-fold (1.40 log units) above; measured number outside the range, below it.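

In this assay, for the compounds shown here, the chloro on the aromatic carbon between two ring nitrogen atoms gives the first single change that can be read, with a 31-fold lower number from compound 2 to compound 3 (1.49 log units; beyond the scatter). This shows that the position is not indifferent to substitution: one chlorine atom in place of hydrogen, meta to a chloro group, moves the read-out well beyond the scatter towards stronger inhibition. Nothing measured here accounts for the size of this step.

From the compounds shown here alone, it remains open whether this shift is particular to chloro or would also appear with another group on the same carbon, such as an amine or a methyl group. Going by these compounds, it is equally open whether the step depends on the other chloro group or on the side chain shared by compound 2 and compound 3.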